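A few compounds are considered here, and "the series" means these few. Any claim that something is new, unique, unknown or untested is made for them only; others in the source may bear on it.

In a functional assay on HCT-116 cells (Homo sapiens) for cytotoxicity, read by sulforhodamine B assay, with a stated time of 72 h (a lower number here means a stronger inhibitor, a higher number a weaker inhibitor), three compounds sharing one core have been measured. Compound 1 `C=C1C(=O)O[C@@H]2CC(C)=C([C@@H](C)CCCOC(C)=O)[C@@H](OC(=O)COc3ccc(C(=O)OCCC)cc3)[C@H]12` gives 37500 nM. Compound 2 `C=C1C(=O)O[C@@H]2CC(C)=C([C@@H](C)CCCOC(C)=O)[C@@H](OC(=O)COc3ccc([N+](=O)[O-])cc3[N+](=O)[O-])[C@H]12` gives > 100000 nM, which is a limit of the assay and not a number. Compound 3 `C=C1C(=O)O[C@@H]2CC(C)=C([C@@H](C)CCCOC(C)=O)[C@@H](OC(=O)COc3cccc4cccnc34)[C@H]12` gives 12100 nM, the lowest number of the three. The series shows an at least 2.6-fold higher number from compound 1 to compound 2 (0.42 log units; beyond the scatter). It also shows a 3.1-fold lower number from compound 1 to compound 3 (0.49 log units; beyond the scatter), and an at least 8.2-fold lower number from compound 2 to compound 3 (0.91 log units; beyond the scatter).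

Compound 4 `C=C1C(=O)O[C@@H]2CC(C)=C([C@@H](C)CCCOC(C)=O)[C@@H](OC(=O)c3ccc(F)cc3)[C@H]12` has not yet been measured. The change leading to it is 4-fluorophenyl in place of ((quinolin-8-yl)oxy)methyl on a carbonyl carbon. Among the measured compounds shown here, no measured step makes this exact exchange. The closest guides are the two steps that end at compound 3, since both concern the same side of the compound and both replace another group with quinolin-8-yl. Each of them lowers the number by a modest amount or more, so removing the quinolin-8-yl group is expected to push the value upward rather than downward. That expectation is held loosely, and the step is expected to stay small, starting from compound 3 at 12100 nM. The estimated change is a 1.7-fold higher number from compound 3 to compound 4 (0.22 log units; within the scatter). For compound 4 the estimated value in this assay is 20000 nM, with an expected range of 6000 nM to 70000 nM.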

Compound 4, half-maximal inhibitory concentration: 14900 nM
For compound 4 the middle estimate is 1.3-fold (0.13 log units) above the measured one; measured number inside the range.
By their numbers in this assay, from the lowest: compounds 3 and 4 (each within the scatter of the next); then compound 1. At a limit, above all of these: compound 2.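

In this assay, replacing ((quinolin-8-yl)oxy)methyl with 4-fluorophenyl on a carbonyl carbon gives a 1.2-fold higher number from compound 3 to compound 4 (0.09 log units; within the scatter). The earlier steps varied only the group on the oxygen of the ((aryl)oxy)methyl unit, whereas this one removes that unit altogether, along with its nitrogen, its oxygen and the six-membered aromatic ring with a hetero atom, and the number stays within the scatter, so among the compounds shown none of these parts is required for a value at this level. Nothing measured on these compounds bears on why this exchange leaves the number within the scatter.

The compounds shown leave open whether the fluorine of the 4-fluorophenyl group matters at all, and whether a plain phenyl, a saturated alkyl chain or an aromatic ring carrying an amine or a carboxylic acid on the same carbonyl carbon would keep the number in this range. From the compounds shown here alone, all four compounds also share one core, so it remains open whether this exchange would behave the same way on a different core.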